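Cytotoxicity notes on a methoxy to nitro change

The source may hold more compounds than are shown below. What is called first, only, known or untested is meant among the compounds shown, and "the series" means these compounds.

Measured so far:
- compound 1 `COc1ccc(CSc2nc(Cc3cc(C(F)(F)F)cc(C(F)(F)F)c3)c(C)c(=O)[nH]2)cc1`: > 256000 nM
- compound 2 `Cc1c(Cc2cc(C(F)(F)F)cc(C(F)(F)F)c2)nc(SCc2ccc([N+](=O)[O-])cc2)[nH]c1=O`: > 248000 nM
- compound 3 `CCc1c(Cc2ccccc2Br)nc(SCc2ccc(OC)cc2)[nH]c1=O`: 165000 nM

In an ADME assay on MT4 cells (Homo sapiens) for cytotoxicity, read by MTT assay (on this read-out lower numbers stand for higher toxicity in this test and higher numbers for lower toxicity in this test), compound 1 gives > 256000 nM, which is a limit of the assay and not a number. Compound 2 likewise gives only a limit in this assay, namely > 248000 nM. Going by the values given here, compound 3 gives the single real number of the set, 165000 nM in this assay. The change from compound 1 to compound 2 is nitro in place of methoxy on an aromatic carbon. Its step is a step that the two limits leave unreadable from compound 1 to compound 2 because the limit of > 256000 nM in this assay, at which 1 of the 3 values shown sits, and the limit of > 248000 nM in this assay, at which 1 of the 3 values shown sits, bound both ends of it.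

How the core of compound 3 differs from the core of compound 1 is not broken down here. Compound 4 `CCc1c(Cc2ccccc2Br)nc(SCc2ccc([N+](=O)[O-])cc2)[nH]c1=O` has not yet been measured; it carries the same change relative to compound 3, (nitro in place of methoxy on an aromatic carbon), at a place described in identical words. The earlier pair gives no readable size, so the expectation rests on compound 3 itself with its 165000 nM and on a step of unknown size. The step from compound 3 to compound 4 is expected to be about a 1.0-fold higher number from compound 3 to compound 4 (0.01 log units; within the scatter). Compound 4 is therefore estimated at 170000 nM in this assay, with a range from 80000 nM to 300000 nM.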

Compound 4, half-maximal cytotoxic concentration: > 272000 nM
Compound 4 gave a limit, no number; the forecaster's own chance of this, stated with the estimate: 35%; middle value at least 1.6-fold (0.20 log units) away from the limit.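

In this assay compound 4 gives > 272000 nM, which is a limit of the assay and not a number. On the core of compound 3, the change from 4-methoxyphenyl to 4-nitrophenyl gives an at least 1.6-fold higher number from compound 3 to compound 4 (0.21 log units; that floor lies within the scatter), so only a floor is known, and that floor does not separate the pair beyond the usual scatter. Going by these compounds alone, the same change on the core of compound 1 cannot be read, so nothing shows that the step has the same size on both cores; what carries over is only that both nitro compounds, compound 2 and compound 4, end in limits.

Still open, from the compounds shown here alone, is whether an amine or a carboxylic acid in the place of the nitro group would give a number rather than a limit on either core. Also open, going by these compounds, is whether a longer chain on either core would bring these values to numbers that can be compared.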